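A few compounds are considered here, and "the series" means these few. Any claim that something is new, unique, unknown or untested is made for them only; others in the source may bear on it.

Measured so far in a functional assay on PANC-1 cells (Homo sapiens) for antiproliferative activity, read by sulforhodamine B assay, with a stated time of 48 h; a lower number here means a stronger inhibitor of growth, a higher number a weaker inhibitor of growth: compound 1 `CCc1nc2nc(C(F)(F)F)ccc2c(=O)n1Cc1cn(CC(=O)Nc2ccccc2)nn1` gives 320 nM; compound 2 `O=C(Cn1cc(COc2nc(-c3ccccc3)nc3nc(C(F)(F)F)ccc23)nn1)Nc1ccccc1` gives 4500 nM; compound 3 `CCCCCCCCCCn1cc(COc2nc(-c3ccccc3)nc3nc(C(F)(F)F)ccc23)nn1` gives 490 nM.

Compound 3 stands second highest of the three numbers; compound 1 lies within the scatter of it, while compound 2 sits well beyond, as the step of a 9.2-fold lower number from compound 2 to compound 3 (0.96 log units; beyond the scatter) shows. Compound 4 `COc1cc(-n2cc(COc3nc(-c4ccccc4)nc4nc(C(F)(F)F)ccc34)nn2)cc(OC)c1OC` differs from compound 3 by 3,4,5-trimethoxyphenyl in place of decyl on an aromatic nitrogen. Going by the values given here, no measured step swaps the group on that aromatic nitrogen for an aromatic ring, so the one step that bears on this position is a 9.2-fold lower number from compound 2 to compound 3 (0.96 log units; beyond the scatter), which only says that the decyl chain gave a markedly lower number than a phenylcarbamoylmethyl group. Moving away from the decyl chain is therefore expected to cost, with the estimated step of a 3.1-fold higher number from compound 3 to compound 4 (0.49 log units; beyond the scatter) in this assay. Compound 4 is estimated at 1500 nM, range 300 nM to 7000 nM.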

Compound 4, concentration for 50% growth inhibition: 820 nM
Beside the measured number, compound 4's estimate is 1.8-fold (0.26 log units) above it; the measured number falls inside the stated range.
By their numbers in this assay, from the lowest: compounds 1, 3 and 4 (each within the scatter of the next, the first and the last beyond it); then compound 2.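

In this assay the aromatic nitrogen of the five-membered ring accepts an aromatic ring as well as a chain: a 1.7-fold higher number from compound 3 to compound 4 (0.22 log units; within the scatter) leaves 3,4,5-trimethoxyphenyl and decyl indistinguishable. The gain over (phenylcarbamoyl)methyl is thus not confined to decyl, as a 5.5-fold lower number from compound 2 to compound 4 (0.74 log units; beyond the scatter) shows. No evidence on the cause is available.

Going by these compounds, whether the methoxy groups matter stays open. So does how an unsubstituted phenyl, a shorter alkyl chain, or a chain ending in an amine or a carboxylic acid would behave on this nitrogen.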